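This account rests on a few compounds, and the source may have more. Where it says the series, first, only, none or still open, it means among the compounds named here.

Working notes on the series. Compound 2 `CCN1C(=O)S/C(=C\c2ccc(N)cc2)C1=O` gives 91000 nM in a functional assay on CCRF-CEM cells (Homo sapiens) for cytotoxicity, read by cell counting, with a stated time of 3 days; on this read-out lower numbers stand for stronger inhibition and higher numbers for weaker inhibition. Of the two numbers reported, that of compound 2 is the higher; the nearer one belongs to compound 1 `C=C(Br)C(=O)Nc1ccc(/C=C2\SC(=O)N(CC)C2=O)cc1`, which in this assay gives 870 nM, so that a 100-fold higher number from compound 1 to compound 2 (2.02 log units; beyond the scatter). Compound 3 `Cc1ccc(CN2C(=O)S/C(=C\c3cccc(N)c3)C2=O)cc1` returns only a limit in this assay, > 250000 nM. That limit of > 250000 nM in this assay, at which 1 of the 3 values shown sits, is one of the values shown here.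

Compound 4 `Nc1ccc(/C=C2\SC(=O)N(Cc3cccc(F)c3)C2=O)cc1` is not yet measured. It differs from compound 2 in one place: 3-fluorophenyl in place of methyl on a saturated chain carbon bound to an amide-type nitrogen in a ring. No measured step in this assay changes the group on that saturated chain carbon alone; the only step shown, from compound 1 to compound 2, concerns the nitrogen on the aromatic ring and does not bear on this change. For the measured compounds named here, compound 3, which also carries a benzyl-type group at the same place, differs from compound 2 in a second place as well, so its limit gives no step. With nothing to set the size of the change, the number for compound 4 is expected near that of compound 2, and the step from compound 2 to compound 4 is estimated as a 1.3-fold higher number from compound 2 to compound 4 (0.12 log units; within the scatter). Compound 4 is thus expected at about 120000 nM, between 30000 nM and 400000 nM.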

Compound 4, half-maximal inhibitory concentration: 116000 nM
Beside the measured number, compound 4's estimate is 1.0-fold (0.01 log units) above it; the range from low to high includes it.
By their numbers in this assay, from the lowest: compound 1; then compounds 2 and 4 (each within the scatter of the next). At a limit, above all of these: compound 3.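

In this assay the saturated chain carbon bound to an amide-type nitrogen in a ring now has a step of its own: 3-fluorophenyl in place of methyl gives a 1.3-fold higher number from compound 2 to compound 4 (0.11 log units; within the scatter), so a six-membered aromatic ring at this place leaves the number within the scatter. The only large step shown remains a 100-fold higher number from compound 1 to compound 2 (2.02 log units; beyond the scatter), and it lies at a different place, the nitrogen on the aromatic ring. Nothing measured here gives a cause for the small size of the new step.

From the compounds shown here alone, whether a carboxylic acid, an amine or a longer chain at this place would behave like 3-fluorophenyl remains open. Also open, going by these compounds, is whether 3-fluorophenyl would leave the number as little changed with the (1-bromoethenyl)carbonyl group of compound 1 on the aromatic nitrogen.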